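Spiro hydantoin anticonvulsants: substituent on the ring amide nitrogen

This account rests on a few compounds, and the source may have more. Where it says the series, first, only, none or still open, it means among the compounds named here.

Compound 2 `CC(C)N1C(=O)NC2(CC2c2ccc3cccc(OCc4ccccc4)c3n2)C1=O` bears an isopropyl on an amide-type nitrogen in a ring; in a functional assay on the whole organism (strain Kunming) with Mus musculus as the target, in the maximal electroshock model, with a stated time of 0.5 h (on this read-out higher numbers stand for an effect only at larger amounts of compound and lower numbers for an effect already at smaller amounts), compound 2 gives 300 mg/kg. Compound 1 `O=C1NC2(CC2c2ccc3cccc(OCc4ccccc4)c3n2)C(=O)N1c1ccc(Cl)cc1`, with 4-chlorophenyl at that nitrogen, gives 300 mg/kg, and compound 3 `O=C1NC(=O)C2(CC2c2ccc3cccc(OCc4ccccc4)c3n2)N1`, with hydrogen there, gives 300 mg/kg. The steps of no change at the digits printed from compound 1 to compound 2 (within the scatter), no change at the digits printed from compound 1 to compound 3 (within the scatter) and no change at the digits printed from compound 2 to compound 3 (within the scatter) all stay within the scatter, so compound 2 stands level with compounds 1 and 3.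

Compound 4 `CN1C(=O)NC2(CC2c2ccc3cccc(OCc4ccccc4)c3n2)C1=O` differs from compound 2 by methyl in place of isopropyl on an amide-type nitrogen in a ring. All three measured steps concern this same nitrogen, and none moved the readout beyond the scatter, so no step beyond the scatter is expected in this assay. For compound 4 the expected value is 300 mg/kg, within 150 mg/kg to 600 mg/kg. This means an expected step of no change at the digits printed from compound 2 to compound 4 (within the scatter).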

Compound 4, minimum effective dose: 100 mg/kg
Compound 4: middle estimate off by 3.0-fold (0.48 log units), on the high side, and the stated range ends above it.
By their numbers in this assay, from the lowest: compound 4; then compounds 1, 2 and 3 (each within the scatter of the next).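

In this assay this nitrogen turns out not to be indifferent to its substituent: methyl stands apart, with a 3.0-fold lower number from compound 2 to compound 4 (0.48 log units; beyond the scatter), a 3.0-fold lower number from compound 3 to compound 4 (0.48 log units; beyond the scatter) and a 3.0-fold lower number from compound 1 to compound 4 (0.48 log units; beyond the scatter). The result follows no steady trend with group size, as hydrogen in compound 3 and isopropyl in compound 2 both sit at the higher number, while methyl falls between them in size. Nothing at hand explains the methyl result.

Open, as far as these compounds go, is whether ethyl or a longer chain such as n-propyl keeps the lower number of compound 4, or whether it is confined to methyl.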